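The compounds below may be only part of what the source reports. "The series", "measured", "known", "first", "only" and "open" are said of these compounds alone.

Measured compounds:
- compound 1, `Cc1ccc(NS(=O)(=O)c2ccc3c(c2)C(=O)CC(C2CCOCC2)O3)c(C)c1`, 2.75
- compound 2, `Cc1ccc(N(CC(C)C)S(=O)(=O)c2ccc3c(c2)C(=O)CC(C2CCOCC2)O3)c(C)c1`, 4.28
- compound 3, `CCc1ccc(N(CC(C)C)S(=O)(=O)c2ccc3c(c2)C(=O)CC(C2CCN(C(=O)C4CCCC4)CC2)O3)cc1`, 5.13

In a physicochemical assay for lipophilicity, at pH 7.4 (on this read-out lower numbers stand for lower lipophilicity and higher numbers for higher lipophilicity), compound 1 holds the lowest of the three numbers. Its nearest neighbour is compound 2, reached by the step of a number 1.53 log units higher from compound 1 to compound 2 (beyond the scatter), which changes the nitrogen substituent, not the aryl group. Compound 3 lies further away still, at 5.13, but it differs from compound 1 in more than one place, so its value shows only where a more heavily altered analogue ends up.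

Compound 4, `CCc1ccc(NS(=O)(=O)c2ccc3c(c2)C(=O)CC(C2CCOCC2)O3)cc1`, arises from compound 1 by 4-ethylphenyl in place of 2,4-dimethylphenyl on a sulfonamide nitrogen. Among the compounds with values here, none of the measured steps concerns this kind of change: the single counted step, from compound 1 to compound 2, alters a different position and is large. The two aryl groups exchanged here carry the same atoms, joined differently, and neither gains nor loses a donor or acceptor, so in this assay the account expects compound 4 to stay close to compound 1, with a step of a number 0.05 log units lower from compound 1 to compound 4 (within the scatter) that is not expected to exceed the scatter. The estimate for compound 4 is 2.7, within 2.35 to 3.05.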

Compound 4, distribution coefficient: 2.67
Beside the measured number, compound 4's estimate is 0.03 log units above it; the measured number falls inside the stated range.
By their numbers in this assay, from the lowest: compounds 4 and 1 (each within the scatter of the next); then compound 2; then compound 3.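

Within the data shown here, at the aryl group on the sulfonamide nitrogen, the earlier compounds offered no single change to read. In this assay, 4-ethylphenyl in place of 2,4-dimethylphenyl now gives a number 0.08 log units lower from compound 1 to compound 4 (within the scatter), so rejoining the same carbon atoms, with no hydrogen-bond donor or acceptor entering or leaving, keeps the read-out within the scatter, unlike the isobutyl change on the same nitrogen, a number 1.53 log units higher from compound 1 to compound 2 (beyond the scatter). No measurement accompanies this result that could explain it.

As far as these compounds go, it remains open whether a phenyl bearing a longer chain, a carboxylic acid or an amine would stay as close to compound 1. From the compounds shown here alone, it also remains open whether this aryl exchange would behave alike with isobutyl on the nitrogen, since compound 3 differs from compound 2 in more than one place.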